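A few compounds are considered here, and "the series" means these few. Any claim that something is new, unique, unknown or untested is made for them only; others in the source may bear on it.

Compound 1 `COCOc1cc(/C=C/C(=O)OCC(=O)Nc2ccc(OC)cc2)ccc1OCc1ccccc1` carries the shared core of this small series. In a functional assay on CNE cells (Homo sapiens) for cytotoxicity, read by MTT assay, with a stated time of 72 h (on this read-out lower numbers stand for stronger inhibition and higher numbers for weaker inhibition), compound 1 gives only a limit, > 200000 nM. Compound 2 `COCOc1cc(/C=C/C(=O)OCC(=O)Nc2nccs2)ccc1OCc1ccccc1` keeps that core and carries a 1,3-thiazol-2-yl in place of the 4-methoxyphenyl on the amide-type nitrogen. In this assay compound 2 likewise gives only a limit, > 200000 nM. The step that the two limits leave unreadable from compound 1 to compound 2 can therefore not be read in size or direction, since both values sit at the limit of > 200000 nM in this assay, at which 2 of the 2 values shown sit. Compound 2 thus stands at the limit of the assay, and the numbers place it on no other footing than compound 1.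

Compound 3 `COCOc1cc(/C=C/C(=O)OCC(=O)NCc2ccco2)ccc1OCc1ccccc1` differs from compound 2 in one place: (furan-2-yl)methyl in place of 1,3-thiazol-2-yl on an amide-type nitrogen. Among the measured compounds shown here, the only measured step, a step that the two limits leave unreadable from compound 1 to compound 2, also exchanges the group on this nitrogen and tells nothing about size, so no direction can be drawn from it. The expectation is therefore that the change in this assay stays unreadable as well, which as an expected step reads a number no higher from compound 2 to compound 3 (the limit leaves the size open). Compound 3 is accordingly estimated at 200000 nM in this assay, with an expected range from 50000 nM to 800000 nM, and most probably again reported only as a limit.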

Compound 3, half-maximal inhibitory concentration: > 200000 nM
Compound 3: only a limit was reported (the forecaster's own chance of this, stated with the estimate: 80%); the middle value sits exactly at the limit.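

In this assay compound 3 gives only a limit, > 200000 nM. The steps among compound 1, compound 2 and compound 3 therefore cannot be read in size or direction: the limit of > 200000 nM in this assay, at which 3 of the 3 values shown sit. The compounds shown leave open how the three compare in this read-out, and whether any group on the amide-type nitrogen gives a readable value.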